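The source may hold more compounds than are shown below. What is called first, only, known or untested is meant among the compounds shown, and "the series" means these compounds.

Measured compounds in a toxicity assay on HEK-293T cells (Homo sapiens) for cytotoxicity, read by MTT assay, with a stated time of 48 h; a lower number here means a stronger inhibitor, a higher number a weaker inhibitor:

Compound 1, `C=C1[C@H](OC(C)=O)[C@@H](OC(C)=O)[C@@H](OC(C)=O)C(C)(C)/C=C/[C@H](C)[C@H](OC(=O)c2ccccc2)[C@@]2(O)C[C@@](C)(OC(=O)C(C)(C)C)[C@H](OC(C)=O)[C@@H]2[C@H]1OCC(C)C`: 56300 nM
Compound 2, `C=C1[C@H](OC(C)=O)[C@@H](OC(C)=O)[C@@H](OC(C)=O)C(C)(C)/C=C/[C@H](C)[C@H](OC(=O)c2ccccc2)[C@@]2(O)C[C@@](C)(OC(=O)c3cccc(C)c3)[C@H](OC(C)=O)[C@@H]2[C@H]1OCC(C)C`: 7220 nM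
Compound 3, `C=C1[C@H](OC(C)=O)[C@@H](OC(=O)c2cccc(C)c2)[C@@H](OC(C)=O)C(C)(C)/C=C/[C@H](C)[C@H]2O[C@]3(C)C[C@@]2(OC(=O)c2ccccc2)[C@H]([C@H]3OC(C)=O)[C@H]1OCC(C)C`: > 100000 nM (a limit of the assay, not a number)

Compounds 1 and 2 share one core and differ in a single place: tert-butyl in place of 3-methylphenyl on a carbonyl carbon. In this assay the step of a 7.8-fold higher number from compound 2 to compound 1 (0.89 log units; beyond the scatter); the tert-butyl ester therefore gives the higher number of the pair.

Compound 3 sits on a different core. How the core of compound 3 differs from that of compound 2 is not broken down here. For compound 3 this assay returns only a limit, (the limit of > 100000 nM in this assay, at which 1 of the 3 values shown sits), so no number stands for it.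

Compound 4, `C=C1[C@H](OC(C)=O)[C@@H](OC(=O)C(C)(C)C)[C@@H](OC(C)=O)C(C)(C)/C=C/[C@H](C)[C@H]2O[C@]3(C)C[C@@]2(OC(=O)c2ccccc2)[C@H]([C@H]3OC(C)=O)[C@H]1OCC(C)C`, is not yet measured. It differs from compound 3 by the same kind of change seen from compound 2 to compound 1: tert-butyl in place of 3-methylphenyl on a carbonyl carbon. The two place descriptions read the same word for word, so nothing around the place differs.

The expectation for compound 4 rests on two things: the step seen for the same change on the other core, a 7.8-fold higher number from compound 2 to compound 1 (0.89 log units; beyond the scatter), which raised the number, and the fact that compound 3 already returns only a limit, > 100000 nM. Carrying the earlier step onto a starting point that is itself a limit, compound 4 is expected to show a step that the limit leaves unreadable from compound 3 to compound 4, with the number most likely again reported only as a limit. The estimate for compound 4 in this assay is 300000 nM, ranging from 100000 nM to 1000000 nM.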

Compound 4, half-maximal inhibitory concentration: > 100000 nM
Compound 4 was reported as a limit; the forecaster's own chance of this, stated with the estimate: 85%; the middle value is on the limit's open side.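

In this assay compound 4 gives > 100000 nM, a limit of the assay and not a number. Compound 3 also stands at a limit, so no step can be read between compound 3 and compound 4: the limit of > 100000 nM in this assay, at which 2 of the 4 values shown sit.

The compounds shown leave open whether tert-butyl in place of 3-methylphenyl on a carbonyl carbon raises the number on the core of compound 3 as it does on the core of compound 2.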